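The compounds below may be only part of what the source reports. "The series", "measured", "known", "first", "only" and "open" are said of these compounds alone.

Compounds measured:
Compound 1 `C=Cc1ccc(S(=O)(=O)Nc2ccc3oc(-c4ccccc4)nc3c2)cc1`, tested in an assay on cells for inhibition of HSP60/HSP10 (Homo sapiens), with a stated time of 60 min (a lower number here means a stronger inhibitor, a higher number a weaker inhibitor), gives > 100000 nM, which is a limit of the assay and not a number.
Compound 2 `O=S(=O)(Nc1ccc(-c2nc3ccccc3o2)cc1)c1cccc(C(F)(F)F)c1`, in this assay, gives 57000 nM.

Compound 1 stands at the weak end of what has been measured: it sits at the limit of > 100000 nM in this assay, at which 1 of the 2 values shown sits, so only a limit is known for it. Compound 2 gives a number, but a high one, and neither compound shows strong inhibition.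

Compound 3 `O=S(=O)(Nc1ccc2oc(-c3ccccc3)nc2c1)c1ccccc1O` has not yet been tested. It differs from compound 1 in one place, (2-hydroxyphenyl in place of 4-vinylphenyl on a sulfonyl sulfur). The phenyl ring on the sulfonyl sulfur remains, its substituent changes. Among the measured compounds shown here, no measured pair of compounds here shows such a step, so its size can only be guessed. Since compound 1 shows > 100000 nM, a limit, there is no firm number to move from.

The step from compound 1 to compound 3 is expected to be an at least 1.4-fold lower number from compound 1 to compound 3 (0.15 log units; that floor lies within the scatter), small and uncertain in direction. Compound 3 is therefore expected to give about 70000 nM, within a range from 15000 nM to 300000 nM, with a fair chance that only a limit is reported again.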

Compound 3, half-maximal inhibitory concentration: 85000 nM
For compound 3 the middle estimate is 1.2-fold (0.08 log units) below the measured one, and the stated range covers the measured number.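

Swapping 4-vinylphenyl for 2-hydroxyphenyl on a sulfonyl sulfur yields a number on the core of compound 1: in this assay, compound 3 gives 85000 nM, so this position now has a measured reading, though still a high one. Compound 1 gives > 100000 nM, which is a limit of the assay and not a number. The change therefore reads only as an at least 1.1-fold lower number from compound 1 to compound 3 (0.07 log units; that floor lies within the scatter), a floor and not a size, and the true step could be larger, with the one limit among the values setting that floor: the limit of > 100000 nM in this assay, at which 1 of the 3 values shown sits.

The compounds shown leave open which part of the change matters, since the vinyl group leaves and the hydroxy group enters in a single step, and a plain phenyl ring on the sulfonyl sulfur would be needed to separate the two. They also leave open how an amine or a carboxylic acid would read in place of the hydroxy group, and whether any such group on this ring can bring the number far down in this assay.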